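This account rests on a few compounds, and the source may have more. Where it says the series, first, only, none or still open, it means among the compounds named here.

Compound 1 `COc1ccc(-c2nc(C)c(C(=O)CSc3nc(-c4ccc(Cl)cc4)c(C#N)c(=O)[nH]3)s2)cc1`, compound 2 `COc1ccc(-c2nc(C)c(C(=O)CSc3nc(-c4ccc(OC)c(OC)c4)c(C#N)c(=O)[nH]3)s2)cc1` and compound 3 `COc1ccc(-c2nc(SCC(=O)c3sc(-c4ccccc4)nc3C)[nH]c(=O)c2C#N)cc1OC` share a core and were each tested in a functional assay on U-87MG ATCC cells for antiproliferative activity against U-87 MG (Homo sapiens), read by MTT assay, with a stated time of 48 h, tested at 100 uM; on this read-out higher numbers stand for a weaker effect at the one concentration tested and lower numbers for a stronger effect. Compound 1 gives 2.85%, compound 2 gives 5.39% and compound 3 gives 6.48%. The change 4-chlorophenyl in place of 3,4-dimethoxyphenyl on an aromatic carbon produced the step of a number 2.5 percentage points lower from compound 2 to compound 1 (within the scatter), and the cores of compound 2 and compound 3 differ by hydrogen in place of methoxy on an aromatic carbon, which gave a number 1.1 percentage points higher from compound 2 to compound 3 (within the scatter). Compound 4 `Cc1nc(-c2ccccc2)sc1C(=O)CSc1nc(-c2ccc(Cl)cc2)c(C#N)c(=O)[nH]1` has not yet been measured; it arises from compound 3 by 4-chlorophenyl in place of 3,4-dimethoxyphenyl on an aromatic carbon, the same change as that from compound 2 to compound 1, at the same place. Because the earlier step of a number 2.5 percentage points lower from compound 2 to compound 1 (within the scatter) lay within the scatter, the expected step of a number 2 percentage points lower from compound 3 to compound 4 (within the scatter) is likewise small. The estimate for compound 4 in this assay is therefore 4.5%, expected to lie between 0% and 12%.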

Compound 4, a percentage reported as activity, at one concentration (the size of the read-out at that concentration, not a potency): 22.5%
Beside the measured number, compound 4's estimate is 18 percentage points below it; the measured number lies above the stated range.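

The change to 4-chlorophenyl in place of 3,4-dimethoxyphenyl did not carry from one core to the other in this assay, where it gave a number 16 percentage points higher from compound 3 to compound 4 (beyond the scatter), and the two steps differ: the same change on two cores in this assay, a number 2.5 percentage points lower (within the scatter) from compound 2 to compound 1 and a number 16 percentage points higher (beyond the scatter) from compound 3 to compound 4, 18.6 percentage points apart, beyond the scatter of two such steps

Hydrogen in place of methoxy likewise gave a number 19.7 percentage points higher from compound 1 to compound 4 (beyond the scatter), and this step also differs from its earlier counterpart: the same change on two cores in this assay, a number 1.1 percentage points higher (within the scatter) from compound 2 to compound 3 and a number 19.7 percentage points higher (beyond the scatter) from compound 1 to compound 4, 18.6 percentage points apart, beyond the scatter of two such steps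

The two changes therefore do not act independently across these four compounds, but the result rests on a single pair of cores at one concentration and does not show why they interact or how the change would behave on any other core.

The compounds shown leave open whether this dependence on the core extends to other groups at this place. Going by these compounds, an amine or a carboxylic acid on that aromatic ring, for example, remains open on either core.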